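The source may hold more compounds than are shown below. What is called first, only, known or untested is meant among the compounds shown, and "the series" means these compounds.

Compound 1 `C=C(C)CC[C@]1(C)C2=CCC[C@](C)(C[C@H](O)c3ccoc3)[C@H]2CC[C@H]1C`: 34000 nM
Compound 2 `CC(C)=CCC[C@]1(C)C2=CCC[C@](C)(CC(=O)c3ccoc3)[C@H]2CC[C@H]1C`: 91000 nM
Compound 3 `C=C(C)CCC[C@]1(C)C2=CCC[C@](C)(C[C@@H](OC(C)=O)C3=CC(=O)OC3O)[C@H]2CC[C@H]1C`: 3200 nM

These three values come from a functional assay on A549 cells (Homo sapiens) for antiproliferative activity, read by XTT assay, with a stated time of 72 h; a lower number here means a stronger inhibitor, a higher number a weaker inhibitor. Compound 1 holds the second highest of the three numbers. Compound 2 is its nearest neighbour on the higher side and compound 3 lies further off on the lower side, and both gaps are beyond the scatter.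

The next compound to be measured is compound 4 `C=C(C)CC[C@]1(C)C2=CCC[C@](C)(C[C@@H](O)c3ccoc3)[C@H]2CC[C@H]1C`. Its relation to compound 1 is this: the two compounds have the same atoms and bonds and differ only in configuration as drawn: 1 of 5 stereo elements differ; a stereocentre at a saturated chain carbon is drawn S in compound 1 and R in compound 4. The only difference is that a stereocentre at a saturated chain carbon is drawn S in compound 1 and R in compound 4. Going by the values given here, no two measured compounds differ in just one place, so the data hold no direct precedent for this change.

The expectation therefore rests on compound 1 at 34000 nM, and no step beyond the scatter is expected in this assay. The expected step is no change at the digits printed from compound 1 to compound 4 (within the scatter). For compound 4 the estimated value is 34000 nM, with an expected range from 13000 nM to 80000 nM.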

Compound 4, half-maximal inhibitory concentration: 34000 nM
The estimate for compound 4 equals the measured number at the digits printed; the measured number falls inside the stated range.
By their numbers in this assay, from the lowest: compound 3; then compounds 1 and 4 (each within the scatter of the next); then compound 2.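

In this assay the record now holds its first step between two compounds that differ in one place, and it reads no change at the digits printed from compound 1 to compound 4 (within the scatter). Inverting the stereocentre at a saturated chain carbon, from S as drawn to R as drawn, therefore leaves the number unmoved on this shared core, which the earlier compounds could not show. The comparison is a clean one, with nothing else to account for, and the step can be read as the effect of this single change: the fact that compounds 1 and 4 differ only in the configuration as drawn

As far as these compounds go, it remains open whether the configuration at this carbon would stay as silent with an amine or a methyl ether in place of the hydroxyl. No other single change from compound 1 or compound 4 can be read from the compounds shown, so what the remaining parts of the structure contribute stays unresolved.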